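A few compounds are considered here, and "the series" means these few. Any claim that something is new, unique, unknown or untested is made for them only; others in the source may bear on it.

Working notes on the series

Compound 1 `CCCCCSc1nc(NCc2ccc([Se]C)cc2)c2ccccc2n1` and compound 2 `CSc1nc(NCc2ccc([Se]C)cc2)c2ccccc2n1` share one core; compound 3 `CCCCC[Se]c1nc(N)c2cccnc2n1` and compound 4 `C[Se]c1nc(N)c2cccnc2n1` share another. The difference between the two cores is not broken down here.

In a functional assay on CCRF-CEM cells (Homo sapiens) for cytotoxicity, read by MTT assay, with a stated time of 72 h (on this read-out lower numbers stand for higher toxicity in this test and higher numbers for lower toxicity in this test), compound 1 gives > 100000 nM, which is a limit of the assay and not a number. In this assay compound 2 gives > 100000 nM, again a limit of the assay. Between them lies (hydrogen in place of butyl on a saturated chain carbon bound to a sulfur), and the step that the two limits leave unreadable from compound 1 to compound 2 cannot be read, since both ends sit at the limit of > 100000 nM in this assay, at which 2 of the 3 values shown sit. In this assay, for the measured compounds named here, compound 3 gives 72600 nM, the only number among the three measured compounds.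

Compound 4 is not yet measured in this assay. From compound 3 it differs by hydrogen in place of butyl on a saturated chain carbon bound to a selenium atom. Going by the values given here, this is the same kind of change as the one from compound 1 to compound 2, but not the same: in the earlier pair the place is on a saturated chain carbon bound to a sulfur, here it is on a saturated chain carbon bound to a selenium atom.

The measured pair gives no readable size for this change, so the expectation rests on compound 3 alone, at 72600 nM, and on the fact that both compounds of the earlier pair sit at the limit of > 100000 nM in this assay, at which 2 of the 3 values shown sit. For compound 4 the step of a 1.5-fold higher number from compound 3 to compound 4 (0.18 log units; within the scatter) is expected to be small, with the value likely near or at the limit. Compound 4 is therefore estimated at 110000 nM, between 40000 nM and 300000 nM.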

Compound 4, concentration lethal to 50% of the cells: > 100000 nM
Compound 4 was reported as a limit; the forecaster's own chance of this, stated with the estimate: 55%; the middle value lies beyond the limit too.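

In this assay compound 4 gives > 100000 nM, which is a limit of the assay and not a number. Going by these compounds, on the core of compound 3, hydrogen in place of butyl on a saturated chain carbon bound to a selenium atom gives an at least 1.3-fold higher number from compound 3 to compound 4 (0.13 log units; that floor lies within the scatter), so this change does not lead to a lower number here and its true size stays unknown, while the related change on the core of compound 1, on a saturated chain carbon bound to a sulfur, cannot be read at all, since both of its ends are limits. Carrying the change from one core to the other therefore yields no two sizes to compare, and the only thing the two pairs share is where their short-chain members end up: the limit of > 100000 nM in this assay, at which 3 of the 4 values shown sit.

On these data alone, whether a longer chain than pentyl, or an amine or a carboxylic acid in place of the pentyl chain, would give a readable number on either core remains open. Also open is how sulfur and selenium compare on a single core, since the compounds shown hold no pair that differs in that one place.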